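Prenyl ether of the hydrazide: where compound 4 may land

The compounds below may be only part of what the source reports. "The series", "measured", "known", "first", "only" and "open" are said of these compounds alone.

Measured compounds:
Compound 1 `CCOc1ccc(C2CC2C(=O)NNC(=O)c2ccncc2)cc1` gives 63000 nM in a functional assay on U-373MG ATCC cells (Homo sapiens) for inhibition, read by MTT assay, with a stated time of 72 h; on this read-out higher numbers stand for weaker inhibition and lower numbers for stronger inhibition.
Compound 2 `CC(C)=CCC/C(C)=C/COc1ccc(C2CC2C(=O)NNC(=O)c2ccncc2)cc1` gives 84000 nM in this assay.
Compound 3 `COc1ccc(C2CC2C(=O)NNC(=O)c2ccncc2)cc1` gives > 100000 nM in this assay, which is a limit of the assay and not a number.

Compound 3 therefore stands at the weak end of the three, at the limit of > 100000 nM in this assay, at which 1 of the 3 values shown sits. The new compound 4 `CC(C)=CCOc1ccc(C2CC2C(=O)NNC(=O)c2ccncc2)cc1` differs from it only at the ether: 2-methylprop-1-en-1-yl in place of hydrogen on a saturated chain carbon bound to an oxygen on an aromatic ring.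

Among the measured compounds shown here, three measured steps bear on this change, all at the same ether carbon. Lengthening methyl to a long branched chain gave a 1.3-fold higher number from compound 1 to compound 2 (0.12 log units; within the scatter). Shortening methyl to hydrogen gave an at least 1.5-fold higher number from compound 1 to compound 3 (0.20 log units; that floor lies within the scatter), and removing the long chain gave an at least 1.1-fold higher number from compound 2 to compound 3 (0.07 log units; that floor lies within the scatter). None of these exceeds the scatter, so the ether substituent has so far made little difference in this assay.

The prenyl group of compound 4 sits between the ethyl of compound 1 and the long chain of compound 2 in size, and the values of those two are within the scatter of each other. Compound 4 is thus expected to show a step of an at least 1.3-fold lower number from compound 3 to compound 4 (0.12 log units; that floor lies within the scatter), essentially no change from compound 3. Compound 4 is estimated at 75000 nM, within 30000 nM to 200000 nM.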

Compound 4, half-maximal inhibitory concentration: > 100000 nM
Compound 4 was reported as a limit; the forecaster's own chance of this, stated with the estimate: 35%; middle value at least 1.3-fold (0.12 log units) from the limit.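

In this assay compound 4 gives > 100000 nM, which is a limit of the assay and not a number. Its comparisons with the two measured ethers are an at least 1.1-fold higher number from compound 2 to compound 4 (0.07 log units; that floor lies within the scatter) and an at least 1.5-fold higher number from compound 1 to compound 4 (0.20 log units; that floor lies within the scatter), while the step from compound 3 cannot be read, since both ends are limits. So the 3-methylbut-2-en-1-yl ether adds a further chain at this oxygen with no gain beyond the scatter, and the comparison now meets the assay's ceiling twice: the limit of > 100000 nM in this assay, at which 2 of the 4 values shown sit.

The compounds shown leave open whether an ether chain ending in an amine or a carboxylic acid, rather than a plain carbon chain, would shift the number beyond the scatter. On these data alone, how far compound 3 and compound 4 truly lie apart also stays open.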